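The compounds below may be only part of what the source reports. "The series", "measured", "known", "first", "only" and "open" are said of these compounds alone.

Measured in a functional assay on KG-1 cells (Homo sapiens) for antiproliferative activity, read by CCK-8 assay, with a stated time of 72 h; on this read-out lower numbers stand for stronger inhibition and higher numbers for weaker inhibition:
- compound 1 `Cc1ccc(C(=O)Nc2cccc(C(F)(F)F)c2)cc1-c1ccc2c(-c3ccc(N4CCN(C)CC4)cc3)n[nH]c2c1` gives 136 nM
- compound 2 `Cc1ccc(C(=O)Nc2cccc(C(F)(F)F)c2)cc1-c1ccc2c(-c3ccc(C(=O)N4CCN(C)CC4)cc3)n[nH]c2c1` gives 300 nM
- compound 3 `Cc1ccc(C(=O)Nc2cccc(C(F)(F)F)c2)cc1-c1ccc2c(-c3cn[nH]c3)n[nH]c2c1` gives > 1000 nM as a limit, not a number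

Compound 3 stands at the limit of > 1000 nM in this assay, at which 1 of the 3 values shown sits, and so has no number to step from. Compound 4 `Cc1ccc(C(=O)Nc2cccc(C(F)(F)F)c2)cc1-c1ccc2c(-c3cnn(C)c3)n[nH]c2c1` carries methyl in place of hydrogen on an aromatic nitrogen and so turns 1H-pyrazol-4-yl into 1-methyl-1H-pyrazol-4-yl.

For the measured compounds named here, no measured step makes this change. Going by the values given here, the only measured step is a 2.2-fold higher number from compound 1 to compound 2 (0.34 log units; beyond the scatter) and it swaps a different group, so it serves only as a loose guide to size. In this assay a step of similar modest size is therefore expected, more likely toward a lower number, though the data do not fix the direction. The expected step is an at least 1.2-fold lower number from compound 3 to compound 4 (0.09 log units; that floor lies within the scatter) on this estimate, and a further limit instead of a number would not surprise. Compound 4 is estimated at 800 nM ( expected range 250 nM to 2500 nM).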

Compound 4, half-maximal inhibitory concentration: 65.7 nM
Compound 4: middle estimate off by 12-fold (1.09 log units), on the high side; measured number below the stated range.
By their numbers in this assay, from the lowest: compound 4; then compound 1; then compound 2. At a limit, above all of these: compound 3.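

In this assay, the aromatic nitrogen of the five-membered ring proves sensitive to a very small change, as adding one methyl gives an at least 15-fold lower number from compound 3 to compound 4 (1.18 log units; beyond the scatter) and turns 1H-pyrazol-4-yl into 1-methyl-1H-pyrazol-4-yl. The value of compound 3 is a limit and not a number: the limit of > 1000 nM in this assay, at which 1 of the 4 values shown sits. For the compounds shown here, the only other step, a 2.2-fold higher number from compound 1 to compound 2 (0.34 log units; beyond the scatter), swaps a different group and is modest, whereas this change at the ring nitrogen is large.

The compounds shown leave open whether a longer chain on this nitrogen, such as ethyl, or a chain ending in an amine or a carboxylic acid, would keep, extend or lose this step. These values also do not tell why a single methyl moves the number this far.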